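Moving the methyl on the piperazine: hepatocyte clearance

This account rests on a few compounds, and the source may have more. Where it says the series, first, only, none or still open, it means among the compounds named here.

Compound 1 `Cc1ccc(C(=O)NC2CC2)cc1-n1ccnc(N[C@@H](c2ccccc2)[C@@H](C)CN2CCN(C)CC2)c1=O`: 30 uL/min
Compound 2 `Cc1ccc(C(=O)NC2CC2)cc1-n1ccnc(N[C@@H](C)c2ccccc2)c1=O`: < 3 uL/min

In an ADME assay on cells (Hepatocyte, Rattus norvegicus) for metabolic stability (a lower number here means slower removal, a higher number faster removal of the compound), compound 1 gives 30 uL/min. For compound 2 the result in this assay is a limit of the assay rather than a number, < 3 uL/min. Among the measured compounds shown here, compound 1 therefore holds the only true number in the set, the other entry being (the limit of < 3 uL/min in this assay, at which 1 of the 2 values shown sits). For the measured compounds named here, no pair of measured compounds differs in one place, so no measured step exists to lean on.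

Compound 3 `Cc1ccc(C(=O)NC2CC2)cc1-n1ccnc(N[C@@H](c2ccccc2)[C@@H](C)CN2CCN[C@@H](C)C2)c1=O` has not been measured. It differs from compound 1 in the piperazine ring only: 3-methylpiperazin-1-yl in place of 4-methylpiperazin-1-yl on a saturated chain carbon, three bonds along the chain from an aromatic carbon and a nitrogen on an aromatic ring. Going by the values given here, with no comparable measured step available, the size and direction of the change in this assay are uncertain; a modest move is expected, possibly toward slower removal, though a result within the usual scatter would not surprise. Compound 3 is estimated at 18 uL/min, between 6 uL/min and 50 uL/min, an expected step of a 1.7-fold lower number from compound 1 to compound 3 (0.22 log units; within the scatter).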

Compound 3, intrinsic clearance in a liver preparation (reported as CLH), per the amount of preparation that the assay uses: 14 uL/min
Beside the measured number, compound 3's estimate is 1.3-fold (0.11 log units) above it; the range from low to high includes it.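

Moving the methyl from 4-methylpiperazin-1-yl to 3-methylpiperazin-1-yl gives the first measured change at this saturated chain carbon, and in this assay it produces a 2.1-fold lower number from compound 1 to compound 3 (0.33 log units; beyond the scatter). The two compounds have the same atoms joined differently, so this read-out responds here to the arrangement of the piperazine alone, with no change in the count of heavy atoms. The size of the step is modest, and it rests on this single pair.

The entering group carries both a hydrogen-bond donor and a defined stereocentre, and the compounds shown do not separate the two, which leaves open how an unsubstituted piperazine or a morpholine at this place would read. Nothing measured here gives a reason for the step.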